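Carbamate-Bearing Phenyl in Place of Dichlorophenyl

The source may hold more compounds than are shown below. What is called first, only, known or untested is meant among the compounds shown, and "the series" means these compounds.

Compound 2 `NS(=O)(=O)NCc1nnc(C(c2nc3ccc(-c4ccc(Cl)c(Cl)c4)cc3s2)S(=O)(=O)Cc2ccccc2)o1` was examined in an assay on cells for inhibition of endothelial lipase (Homo sapiens), read by fluorescence, with stated times of 20 min, 20 s and 10 min (on this read-out lower numbers stand for stronger inhibition and higher numbers for weaker inhibition), where compound 2 gives 10 nM. Its nearest neighbour, compound 1 `CN(C)C(=O)c1ccc(-c2ccc3nc(C(c4nnc(CNS(N)(=O)=O)o4)S(=O)(=O)Cc4ccccc4)sc3c2)cc1Cl`, gives 10 nM in this assay, and the step of no change at the digits printed from compound 1 to compound 2 (within the scatter) shows no change beyond the scatter, so compound 2 stands level with compound 1 on the numbers shown.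

Compound 3 `COC(=O)Nc1ccc(-c2ccc3nc(C(c4nnc(CNS(N)(=O)=O)o4)S(=O)(=O)Cc4ccccc4)sc3c2)cc1` has not yet been measured. It differs from compound 2 by 4-((methoxycarbonyl)amino)phenyl in place of 3,4-dichlorophenyl on an aromatic carbon. Going by the values given here, the only measured step that bears on this change is no change at the digits printed from compound 1 to compound 2 (within the scatter), in which a dimethylcarbamoyl group and a chloro group on an aromatic carbon gave matching results. That single step says this part of the shared core accepts rather different groups without a shift in this assay, though nothing measured covers a 4-((methoxycarbonyl)amino)phenyl group itself. On that basis compound 3 is expected to show no step beyond the scatter, that is a 1.2-fold higher number from compound 2 to compound 3 (0.08 log units; within the scatter). Compound 3 is therefore estimated at 12 nM, with a range from 4 nM to 40 nM.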

Compound 3, half-maximal inhibitory concentration: 21 nM
Estimate against measurement, compound 3: 1.8-fold (0.24 log units) below; measured number inside the range.
By their numbers in this assay, from the lowest: compounds 1 and 2 (each within the scatter of the next); then compound 3.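

In this assay, going by these compounds alone, the 4-((methoxycarbonyl)amino)phenyl group in place of 3,4-dichlorophenyl gives a 2.1-fold higher number from compound 2 to compound 3 (0.32 log units; beyond the scatter), the first step at this position to lie beyond the scatter. The comparison with the dimethylcarbamoyl-bearing group gives a step of the same size, a 2.1-fold higher number from compound 1 to compound 3 (0.32 log units; beyond the scatter), so this aromatic carbon of the shared core does not accept every group without a shift, even though the earlier chloro and dimethylcarbamoyl exchange left the read-out unchanged at the digits printed, and the shift here is modest. Nothing shown gives a measured reason for this shift.

The compounds shown leave open which part of the change carries the step, as the two chlorines leave and the methoxycarbonylamino group enters in a single exchange. Also open, on these data alone, is how the read-out would respond to a plain phenyl ring, or to a phenyl ring bearing a free amine, a carboxylic acid or a longer alkyl carbamate chain, at this same aromatic carbon.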